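A Dimethoxyphenyl Amine Replaces the Trifluoromethylphenyl Amine

The source may hold more compounds than are shown below. What is called first, only, known or untested is meant among the compounds shown, and "the series" means these compounds.

Of the compounds shown here, three sharing one core have been tested in a functional assay on MCF7 cells (Homo sapiens) for cytotoxicity, read by MTT assay, with a stated time of 72 h; a lower number here means a stronger inhibitor, a higher number a weaker inhibitor. Compound 1 `FC(F)(F)c1ccc(CSc2nc(N3CCCCC3)c3ccccc3n2)cc1` carries a piperidin-1-yl group on the core. In this assay compound 1 gives > 50000 nM, which is a limit of the assay rather than a number. Compound 2 `FC(F)(F)c1ccc(CSc2nc(Nc3ccccc3)c3ccccc3n2)cc1` carries an anilino group instead, and in this assay compound 2 gives 44000 nM; the step of an at least 1.1-fold lower number from compound 1 to compound 2 (0.05 log units; that floor lies within the scatter) is small. Compound 3 `FC(F)(F)c1ccc(CSc2nc(Nc3ccc(C(F)(F)F)cc3)c3ccccc3n2)cc1` bears a (4-(trifluoromethyl)phenyl)amino group, and in this assay compound 3 gives 5100 nM, the lowest of the two numbers available. The steps of an at least 9.8-fold lower number from compound 1 to compound 3 (0.99 log units; beyond the scatter) and an 8.6-fold lower number from compound 2 to compound 3 (0.94 log units; beyond the scatter) both lie beyond the scatter and point to the trifluoromethyl group as what sets compound 3 apart.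

Compound 4 `COc1cc(Nc2nc(SCc3ccc(C(F)(F)F)cc3)nc3ccccc23)cc(OC)c1` has not yet been measured. It differs from compound 3 by 3,5-dimethoxyphenyl in place of 4-(trifluoromethyl)phenyl on a nitrogen on an aromatic ring. Among the measured compounds shown here, the measured step of an 8.6-fold lower number from compound 2 to compound 3 (0.94 log units; beyond the scatter) bears directly on this change: the trifluoromethyl group that produced it is removed, while the two methoxy groups that enter have no counterpart among the measured compounds. Compound 4 is therefore expected to give back much of what compound 3 gained, with an estimated step of a 3.5-fold higher number from compound 3 to compound 4 (0.55 log units; beyond the scatter). In this assay compound 4 is estimated at 18000 nM, within a range from 4000 nM to 50000 nM.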

Compound 4, half-maximal inhibitory concentration: 6990 nM
Compound 4: middle estimate off by 2.6-fold (0.41 log units), on the high side, and the stated range covers the measured number.
By their numbers in this assay, from the lowest: compounds 3 and 4 (each within the scatter of the next); then compound 2. At a limit, above all of these: compound 1.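

In this assay, the step of a 1.4-fold higher number from compound 3 to compound 4 (0.14 log units; within the scatter) shows that on this nitrogen the 3,5-dimethoxyphenyl group cannot be told apart from the 4-(trifluoromethyl)phenyl group, so trifluoromethyl is no longer the only substituent tied to a value in this range. The step of a 6.3-fold lower number from compound 2 to compound 4 (0.80 log units; beyond the scatter) confirms the point against the unsubstituted phenyl group, since it lies beyond the scatter and a second, quite different substitution now stands clear of the plain anilino group. Compound 1 stands at a limit of the assay and not at a number, so the step of an at least 7.1-fold lower number from compound 1 to compound 4 (0.85 log units; beyond the scatter) gives only a floor: the limit of > 50000 nM in this assay, at which 1 of the 4 values shown sits.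

The compounds shown leave open whether a single methoxy group, a chlorine or a hydroxyl group on the same phenyl ring would do as much, and which of the two methoxy groups, if either alone, accounts for the step from the plain anilino group. They also leave open what happens when the sulfur link of the shared core gives way to an oxygen or an amine.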